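Morpholinylmethyl Replaced by Isopropyl on the Amide Side Chain

A few compounds are considered here, and "the series" means these few. Any claim that something is new, unique, unknown or untested is made for them only; others in the source may bear on it.

Among the compounds with values here, compound 1 `CNC(=O)c1cc(C(=O)NCCCC2CNCCO2)cn(Cc2ccccc2)c1=O` gives 1.4 in a physicochemical assay for lipophilicity, at pH 7.4 (a lower number here means a more polar compound, a higher number a more lipophilic compound), the lower of the two numbers measured so far. Compound 2 `CNC(=O)c1cc(C(=O)NC2CC2)cn([C@H](C)c2ccccc2)c1=O` gives 3.4 in this assay, a number that lies above compound 1 by more than the usual scatter, but the two compounds differ in several places at once, so that gap says nothing about any single change. Compound 3 `CNC(=O)c1cc(C(=O)NCCC(C)C)cn(Cc2ccccc2)c1=O` has not yet been measured. It differs from compound 1 in one place: isopropyl in place of (morpholin-2-yl)methyl on a saturated chain carbon, two bonds along the chain from an amide-type nitrogen. Because compound 1 stands at 1.4 while compound 2 reaches 3.4 without any such ring on the amide side, a step upward well beyond the scatter is expected, a number 1.60 log units higher from compound 1 to compound 3 (beyond the scatter). For compound 3 the estimate in this assay is 3, within a range from 2.4 to 3.6.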

Compound 3, distribution coefficient: 4.8
Compound 3: middle estimate off by 1.80 log units, on the low side, and the stated range ends below it.
By their numbers in this assay, from the lowest: compound 1; then compound 2; then compound 3.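

In this assay, within the data shown here, the replacement of (morpholin-2-yl)methyl by isopropyl on a saturated chain carbon, two bonds along the chain from an amide-type nitrogen, is the first change in these compounds that can be read on its own, and it gives a number 3.40 log units higher from compound 1 to compound 3 (beyond the scatter). The number at this position thus depends strongly on the group carried by the chain, yet the change removes a six-membered non-aromatic ring with 2 hetero atoms, 1 hydrogen-bond donor and 2 hydrogen-bond acceptors, and this single step cannot separate these features. Nothing measured here ties the step to any one of them.

On these data alone, whether an open-chain amine on the same chain would give a number nearer compound 1 or nearer compound 3 remains open. The same question stands for a carboxylic acid or a longer chain at this place.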